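Replacing an Aryl Amide by an Aryl Ester

A few compounds are considered here, and "the series" means these few. Any claim that something is new, unique, unknown or untested is made for them only; others in the source may bear on it.

Measured compounds:
compound 1 `CCn1c(C(=O)NCCN(C)C)ccc1C(CC)(CC)c1ccc(OCC(O)C(C)(C)C)c(C)c1`: 14 nM
compound 2 `C#CC(C)OC(=O)c1ccc(C(CC)(CC)c2ccc(OCC(O)C(C)(C)C)c(C)c2)n1CC`: 200 nM
compound 3 `CCn1c(C(=O)Nc2cccc(C(F)(F)F)c2)ccc1C(CC)(CC)c1ccc(OCC(O)C(C)(C)C)c(C)c1`: > 50000 nM

The three compounds share one core and differ only in the group attached to a carbonyl carbon. In an assay on HL-60 cells for agonist activity at vitamin D3 receptor (Homo sapiens), read by microscopy, with a stated time of 96 h (on this read-out higher numbers stand for an effect only at larger amounts of compound and lower numbers for an effect already at smaller amounts), compound 1 gives 14 nM, and compound 2 gives 200 nM. For compound 3 the assay reports no number but a limit, > 50000 nM. Compound 3 therefore sits at the limit of > 50000 nM in this assay, at which 1 of the 3 values shown sits, with nothing beyond it to measure. The steps leading there are an at least 3500-fold higher number from compound 1 to compound 3 (3.55 log units; beyond the scatter) and an at least 250-fold higher number from compound 2 to compound 3 (2.39 log units; beyond the scatter).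

Compound 4 `CCn1c(C(=O)Oc2ccc(CCO)cc2)ccc1C(CC)(CC)c1ccc(OCC(O)C(C)(C)C)c(C)c1` carries a group of 10 heavy atoms (8 carbon, 2 oxygen; one six-membered aromatic ring of carbon only) in place of a group of 11 heavy atoms (7 carbon, 1 nitrogen, 3 fluorine; one six-membered aromatic ring of carbon only), on a carbonyl carbon. The step that bears most directly on this is an at least 250-fold higher number from compound 2 to compound 3 (2.39 log units; beyond the scatter), where an ester was exchanged for an aryl amide and the number rose far beyond the scatter. Compound 4 returns to an ester, though its ester bears an aromatic ring like the amide of compound 3. The number for compound 4 is therefore expected to fall below the limit of compound 3, by an at least 33-fold lower number from compound 3 to compound 4 (1.52 log units; beyond the scatter), while not reaching compound 2. Compound 4 is estimated at 1500 nM, within 150 nM to 20000 nM.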

Compound 4, half-maximal effective concentration: 5100 nM
Compound 4: the middle estimate sits 3.4-fold (0.53 log units) below what was measured; low and high end bracket the measured number.
By their numbers in this assay, from the lowest: compound 1; then compound 2; then compound 4. At a limit, above all of these: compound 3.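

In this assay, moving from the aryl amide to an aryl ester bearing a 2-hydroxyethyl chain on its ring gives an at least 9.8-fold lower number from compound 3 to compound 4 (0.99 log units; beyond the scatter). Compound 3 has only a limit and no exact number, so that step is a minimum: the limit of > 50000 nM in this assay, at which 1 of the 4 values shown sits. An aromatic ring on the ester oxygen still does not match the smaller ester group or the amide with its 2-(dimethylamino)ethyl chain, with a 26-fold higher number from compound 2 to compound 4 (1.41 log units; beyond the scatter) and a 360-fold higher number from compound 1 to compound 4 (2.56 log units; beyond the scatter).

Compound 3 and compound 4 differ in the link, an amide nitrogen against an ester oxygen, and also in the ring's substituent, so the shift cannot be assigned to either one alone. Also open, on these data alone, is how a carboxylic acid or a piperidine amide on the same carbonyl carbon would read.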